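Swapping methoxy for cyano on a pendant phenyl ring

The source may hold more compounds than are shown below. What is called first, only, known or untested is meant among the compounds shown, and "the series" means these compounds.

Measured so far:
Compound 1, `N#CN1CC(OCc2ccc(-c3cccnc3)cc2)C1`: 12 nM
Compound 2, `COc1cccc(-c2ccc(COC3CN(C#N)C3)c(C(F)(F)F)c2)c1`: 0.85 nM
Compound 3, `COc1ccccc1-c1cc(Oc2ccccc2)ccc1COC1CN(C#N)C1`: 23.7 nM

All three compounds share a cyanoazetidine ether core and were tested in an assay on isolated protein for inhibition of N-acylethanolamine-hydrolyzing acid amidase (Homo sapiens), read by fluorescence, with a stated time of 90 min; a lower number here means a stronger inhibitor, a higher number a weaker inhibitor. Compound 3 gives 23.7 nM, the highest number of the three. Compound 1, with 12 nM, sits within the usual scatter of compound 3, so the two cannot be told apart on this evidence. Compound 2, with 0.85 nM, lies well beyond the scatter and is clearly the strongest inhibitor here.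

The next compound, compound 4, `N#Cc1ccccc1-c1cc(Oc2ccccc2)ccc1COC1CN(C#N)C1`, has not yet been measured. It differs from compound 3 in one place: cyano in place of methoxy on an aromatic carbon. In other words, the 2-methoxyphenyl of compound 3 becomes a 2-cyanophenyl in compound 4, while the rest of the molecule, including the phenoxy group and the cyanoazetidine ether, is unchanged.

Going by the values given here, no measured pair in this set isolates this particular swap, so there is no direct precedent to lean on. Both groups are small, and both carry one hydrogen-bond acceptor and no donor. The expectation is therefore a step of modest size, most likely staying within the scatter. The expected step is a 1.2-fold lower number from compound 3 to compound 4 (0.07 log units; within the scatter). Compound 4 is expected to give about 20 nM in this assay, with a plausible range from 6 nM to 70 nM.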

Compound 4, half-maximal inhibitory concentration: 6.6 nM
Compound 4: the middle estimate sits 3.0-fold (0.48 log units) above what was measured; the measured number falls inside the stated range.
By their numbers in this assay, from the lowest: compound 2; then compounds 4, 1 and 3 (each within the scatter of the next, the first and the last beyond it).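

Read in this assay, the change from 2-methoxyphenyl to 2-cyanophenyl gives a 3.6-fold lower number from compound 3 to compound 4 (0.56 log units; beyond the scatter), which is the first sign that a group on this ring, ortho to a large group, can shift the result by more than the usual scatter. The two groups match in what can be counted: each has 2 heavy atoms, no ring, 0 hydrogen-bond donors and 1 hydrogen-bond acceptor, so those counts alone do not predict the outcome at this position. No measurement is available that explains why the cyano compound gives the lower number.

This is a single pair, so it establishes only that cyano gives a lower number than methoxy on this particular molecule, and it cannot show whether the same swap would give a step of similar size on a molecule that lacks the phenoxy group. It also leaves open how other groups at this position would compare, such as a single fluorine atom, a primary amide or a carboxylic acid.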